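The source may hold more compounds than are shown below. What is called first, only, known or untested is meant among the compounds shown, and "the series" means these compounds.

Working notes on the series.

For the measured compounds named here, compound 1 `COc1ccc(CNC(=O)/C=C/c2coc3cc(O)ccc3c2=O)cc1` is the first member with a value in a functional assay on HeLa cells (Homo sapiens) for inhibition, read by MTT assay, with a stated time of 48 h; on this read-out higher numbers stand for weaker inhibition and lower numbers for stronger inhibition. In this assay compound 1 reaches only the limit of the assay, > 100000 nM, and gives no number. Compound 2 `COc1ccc2c(=O)c(/C=C/C(=O)Nc3ccccc3Cl)coc2c1` is the second member, and in this assay compound 2 gives 22400 nM. Going by the values given here, compound 2 thus stands as the only numerical value shown in this assay; the remaining value is a limit, as recorded in the limit of > 100000 nM in this assay, at which 1 of the 2 values shown sits.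

Compound 3 `COc1ccc2c(=O)c(/C=C/C(=O)Nc3ccccc3C)coc2c1` has not yet been measured in this assay. It differs from compound 2 by methyl in place of chloro on an aromatic carbon.

Among the compounds with values here, no step between two measured compounds is recorded, so there is nothing to compare this change against. Within the data shown here, with only one number to start from, the expected step from compound 2 to compound 3 in this assay is a 1.1-fold higher number from compound 2 to compound 3 (0.05 log units; within the scatter), which is no more than the usual scatter in either direction. On that basis compound 3 is estimated to give 25000 nM in this assay, with a range from 8000 nM to 80000 nM.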

Compound 3, half-maximal inhibitory concentration: 7270 nM
Compound 3: middle estimate off by 3.4-fold (0.54 log units), on the high side; the measured number lies below the stated range.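

At this place, on an aromatic carbon of a six-membered aromatic ring of carbon only, ortho to a large group, the series now has its first readable step in this assay: methyl in place of chloro gives a 3.1-fold lower number from compound 2 to compound 3 (0.49 log units; beyond the scatter), so compound 3 is the stronger inhibitor of this pair. The exchange swaps one heavy atom for one heavy atom, with no ring, hydrogen-bond donor, hydrogen-bond acceptor or net charge entering or leaving, which shows that the read-out responds to a change this small at this place. No measured property of either group bears on this step, so the data give no cause for it.

On these data alone, whether an amine, a carboxylic acid or a plain hydrogen at this place would lower or raise the number stays open, as does whether a longer chain would follow methyl. Compound 1 holds only a limit and differs from compound 2 and compound 3 in more than one place, so it adds nothing to this reading.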